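The compounds below may be only part of what the source reports. "The series", "measured", "known", "first", "only" and "open" are said of these compounds alone.

Measured in a functional assay on B16-F10 cells (Mus musculus) for antiproliferative activity, read by MTT assay, with a stated time of 48 h; a lower number here means a stronger inhibitor, a higher number a weaker inhibitor:
- compound 1 `CC(=O)N1N=C(c2ccc3ccccc3c2)OC1c1ccccc1Cl`: 4.93 ug/mL
- compound 2 `CC(=O)N1N=C(c2ccc3ccccc3c2)OC1c1ccccc1[N+](=O)[O-]`: 9.01 ug/mL

The values of compound 2 and compound 1 lie within the scatter of each other, so neither ranks ahead of the other. Compound 3 `CC(=O)N1N=C(c2ccc3ccccc3c2)OC1c1ccc([N+](=O)[O-])cc1` has not yet been measured. It differs from compound 2 in one place: 4-nitrophenyl in place of 2-nitrophenyl on a saturated ring carbon. In words, 4-nitrophenyl stands in place of 2-nitrophenyl on a saturated ring carbon.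

For the measured compounds named here, only one measured step bears on this. The step of a 1.8-fold higher number from compound 1 to compound 2 (0.26 log units; within the scatter) put nitro in place of chloro on an aromatic carbon and stayed within the scatter. Going by the values given here, no measured pair shows the nitro group at a different place, so this guide is indirect, and no step beyond the scatter is expected. The expected change is a 1.3-fold lower number from compound 2 to compound 3 (0.11 log units; within the scatter), which is an estimate. Compound 3 is expected at 7 ug/mL, with an estimated range of 3 ug/mL to 16 ug/mL.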

Compound 3, half-maximal inhibitory concentration: 9.32 ug/mL
The estimate for compound 3 lay 1.3-fold (0.12 log units) below the measured number; the range from low to high includes it.
By their numbers in this assay, from the lowest: compounds 1, 2 and 3 (each within the scatter of the next).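

In this assay, 4-nitrophenyl in place of 2-nitrophenyl on the saturated ring carbon gives a 1.0-fold higher number from compound 2 to compound 3 (0.01 log units; within the scatter), so the place of the nitro group on this phenyl ring does not separate these two compounds. Set against the chloro compound, the change gives a 1.9-fold higher number from compound 1 to compound 3 (0.28 log units; within the scatter), which means that no two of the three groups shown at this carbon (2-chlorophenyl, 2-nitrophenyl and 4-nitrophenyl) can be told apart in this assay. Nothing available explains this lack of separation.

The compounds shown leave open whether a phenyl ring carrying an amine or a carboxylic acid at this carbon would also stay within the scatter of these three. As far as these compounds go, it also remains open whether 4-chlorophenyl, or a longer chain in place of the acetyl group, would shift the number beyond it.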